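The source may report more compounds than this note shows. Statements on the series, on what has been measured and on what is new or still open speak of the compounds shown alone.

Measured in a functional assay on HeLa cells (Homo sapiens) for antiproliferative activity, read by sulforhodamine B assay; on this read-out higher numbers stand for weaker inhibition of growth and lower numbers for stronger inhibition of growth:

Compound 1 `CCC[C@@H]1O[C@H](COCc2ccc3ccccc3c2)[C@@H](OCc2ccc3ccccc3c2)[C@H](OCc2ccc3ccccc3c2)[C@H]1OC(C)=O`: > 50000 nM
Compound 2 `O[C@@H]1[C@@H](OCc2ccccc2)[C@H](OCc2ccccc2)[C@@H](COCc2ccccc2)O[C@H]1CC1CC1`: > 50000 nM
Compound 3 `CC(=O)OC[C@H]1O[C@@H](Cc2ccccc2)[C@H](OC(C)=O)[C@@H](OCc2ccccc2)[C@@H]1OC(C)=O`: > 50000 nM

None of these three entries is a number, for each is a limit of the assay, as the limit of > 50000 nM in this assay, at which 3 of the 3 values shown sit, records. As far as these compounds go, compound 3 gives > 50000 nM, which is a limit, so how weak its inhibition of growth really is remains unknown. Among the measured compounds shown here, no step between measured compounds is available to serve as a guide.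

Compound 4 `CC(=O)O[C@@H]1[C@@H](OCc2ccccc2)[C@H](OC(C)=O)[C@@H](COCc2ccccc2)O[C@H]1Cc1ccccc1` is the next compound to be tested. It differs from compound 3 by benzyl in place of acetyl on an oxygen on a saturated carbon, which reads as acetoxymethyl to (benzyloxy)methyl.

With nothing measured below the limit, no change beyond the scatter is expected in this assay. The expected size of the change is an at least 1.1-fold lower number from compound 3 to compound 4 (0.04 log units; that floor lies within the scatter). A result at the same limit is the likeliest outcome. For compound 4 the estimated value is 45000 nM, with an expected range from 12000 nM to 80000 nM.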

Compound 4, concentration for 50% growth inhibition: 5400 nM
Compound 4: the middle estimate sits 8.3-fold (0.92 log units) above what was measured, outside the stated range (below it).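

In this assay compound 4 is the first of the compounds shown to give a number rather than a limit, so growth inhibition on this read-out does respond to what sits on this oxygen on a saturated carbon. Benzyl in place of acetyl there gives an at least 9.2-fold lower number from compound 3 to compound 4 (0.96 log units; beyond the scatter), and that step is only a floor, as its starting value is a limit. The change removes a carbonyl-bearing acetyl and brings in a six-membered aromatic ring of carbon only, but this single pair cannot tell which of the two matters.

As far as these compounds go, it stays open whether a longer chain or an amine on this oxygen would move the number the same way, or whether the aromatic ring is needed. How weak the starting compound truly is also remains unknown, and the same holds for the other compounds held at: the limit of > 50000 nM in this assay, at which 3 of the 4 values shown sit.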